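The source may report more compounds than this note shows. Statements on the series, on what has been measured and on what is new or still open speak of the compounds shown alone.

Working notes on the series follow. In an ADME assay on J774.A1 cells (Mus musculus) for inhibition, read by MTT assay, with a stated time of 72 h (on this read-out higher numbers stand for an effect only at larger amounts of compound and lower numbers for an effect already at smaller amounts), compound 1 (`CC(C)Nc1nc(NCc2ccco2)c2ccccc2n1`) gives 17000 nM. Among the measured compounds shown here, that is the only number available, so compound 1 cannot yet be ranked against anything. For the measured compounds named here, compound 2 (`c1coc(CNc2nc(NC3CCC3)nc3ccccc23)c1`) stands at "not determined" (no result reported), which leaves no measured step to draw on. Compound 3 (`CC(C)Nc1nc(NC(C)C)c2ccccc2n1`) is still unmeasured.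

The change on going to compound 3 is isopropyl in place of (furan-2-yl)methyl on a nitrogen on an aromatic ring and it turns ((furan-2-yl)methyl)amino into isopropylamino, while the rest of the core of compound 1 stays the same. The expectation therefore rests on one anchor, compound 1 at 17000 nM and on the nature of this single replacement. No step beyond the usual scatter is firmly expected in this assay and there is only a slight lean toward higher numbers. The estimated move is a 1.5-fold higher number from compound 1 to compound 3 (0.17 log units; within the scatter) and it remains uncertain with so little data. For compound 3 the expected value is 25000 nM with an estimated range of 8000 nM to 80000 nM in this measurement.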

Compound 3, half-maximal effective concentration: > 30000 nM
Compound 3 ended at the assay's limit (the forecaster's own chance of this, stated with the estimate: 25%); at least 1.2-fold (0.07 log units) between middle value and limit.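

In this assay compound 3 gives > 30000 nM, which is a limit of the assay and not a number: the limit of > 30000 nM in this assay, at which 1 of the 3 values shown sits.

From the compounds shown here alone, this gives the series its first readable step at this position, with isopropyl in place of (furan-2-yl)methyl on a nitrogen on an aromatic ring: an at least 1.7-fold higher number from compound 1 to compound 3 (0.24 log units; that floor lies within the scatter), so the direction is toward higher numbers, while the true size of the step stays unknown and only its floor can be stated. Of the two groups compared at this place, only (furan-2-yl)methyl, with its five-membered aromatic ring, gives a value inside the range of the assay, with compound 1 at 17000 nM, but one pair shows no pattern and cannot separate the loss of that ring from any other part of the change.

Going by these compounds, how far compound 3 lies past its limit remains open, and so does whether the step is larger than ordinary repeat scatter. Also open, on these data alone, is whether a benzyl group, a tetrahydrofuran-2-ylmethyl group or a longer chain such as n-butyl on this nitrogen would give a number nearer that of compound 1 or would also end at the limit.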